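Adding a Fluorine to the Phenyl Group

The source may report more compounds than this note shows. Statements on the series, on what has been measured and on what is new or still open speak of the compounds shown alone.

Of the compounds shown here, two built on one shared core have been tested in a functional assay on HT-29 cells (Homo sapiens) for cytotoxicity, read by MTT assay, with a stated time of 72 h; a lower number here means a stronger inhibitor, a higher number a weaker inhibitor. Compound 1, `Cc1c(C(=O)Nc2ccc(Oc3ccnc4[nH]ccc34)c(F)c2)nnn1-c1ccc(F)cc1`, gives 120 nM. Compound 2, `Cc1c(C(=O)Nc2ccc(Oc3ccnc4[nH]ccc34)cc2)nnn1-c1ccccc1`, gives 350 nM. Among the measured compounds shown here, compound 2 thus stands with the higher of the two numbers, and the gap to compound 1 lies beyond the scatter; the two structures differ in two places, so no single step can be drawn between them.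

Compound 3, `Cc1c(C(=O)Nc2ccc(Oc3ccnc4[nH]ccc34)cc2)nnn1-c1ccc(F)cc1`, has not yet been measured. It differs from compound 2 by fluoro in place of hydrogen on an aromatic carbon and otherwise matches compound 2 exactly. For the measured compounds named here, the only measured compound that carries the 4-fluorophenyl group is compound 1, which also carries a second fluorine on the central ring, so the contribution of the 4-fluorophenyl group on its own cannot be read from the present numbers. The estimated step of a 1.6-fold lower number from compound 2 to compound 3 (0.20 log units; within the scatter) is expected to be a small shift toward a lower number, within or only just beyond the scatter. Compound 3 is therefore expected to give an estimated 220 nM, with a range from 100 nM to 500 nM.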

Compound 3, half-maximal inhibitory concentration: 180 nM
For compound 3 the middle estimate is 1.2-fold (0.09 log units) above the measured one, within the range that was stated.
By their numbers in this assay, from the lowest: compounds 1, 3 and 2 (each within the scatter of the next, the first and the last beyond it).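

In this assay the change from phenyl to 4-fluorophenyl can now be read on its own, and at this position, para to a large group, it gives a 1.9-fold lower number from compound 2 to compound 3 (0.29 log units; within the scatter) with the rest of the molecule unchanged. Compound 3 also isolates the second fluorine of compound 1, which could not be separated from the 4-fluorophenyl group before: hydrogen in its place gives a 1.5-fold higher number from compound 1 to compound 3 (0.18 log units; within the scatter) as the matching single step. Each fluorine, taken alone, therefore stays within the usual scatter of repeated measurements, so neither single step can be told apart from the noise of this test.

From the compounds shown here alone, it remains open whether another group at the same para position, such as chloro, methoxy or an amine, would give a step beyond the scatter. Going by these compounds, it is also open whether a fluorine on a different carbon of the phenyl ring would read the same way. No measurement here offers an explanation for these numbers.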